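A few compounds are considered here, and "the series" means these few. Any claim that something is new, unique, unknown or untested is made for them only; others in the source may bear on it.

Compound 1 `Cc1cc(C)c2c(O)cc(-c3ccc(Cl)cc3)nc2n1` carries a chloro on its pendant aryl ring, and in a functional assay on MDA-MB-435 cells (Homo sapiens) (on this read-out higher numbers stand for weaker inhibition of growth and lower numbers for stronger inhibition of growth), compound 1 gives 4070 nM. That is the only result in the set expressed as a number. Compound 2 `COc1cccc(-c2cc(O)c3c(C)cc(C)nc3n2)c1` runs into the floor of this assay: compound 2 gives < 10 nM, which is a limit and not a number. Compound 3 `COc1cccc(-c2cc(O)c3cccnc3n2)c1` does the same, and in this assay compound 3 gives < 10 nM, again a limit rather than a number. Compound 1 thus stands far away from the limit of < 10 nM in this assay, at which 2 of the 3 values shown sit, and both methoxy-bearing compounds sit at that limit.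

Compound 4 `COc1ccc(-c2cc(O)c3c(C)cc(C)nc3n2)cc1` is the single-change partner of compound 1: methoxy in place of chloro on an aromatic carbon. Within the data shown here, no measured pair in the set follows exactly this change, and neither compound 2 nor compound 3 is a one-step neighbour of compound 4, so the expectation for compound 4 leans on the general tendency rather than on a matched step. Even so, a large step toward stronger inhibition of growth is expected, a 27-fold lower number from compound 1 to compound 4 (1.43 log units; beyond the scatter), because the methoxy-bearing compound 2 and compound 3 both stand at the limit of < 10 nM in this assay, at which 2 of the 3 values shown sit. For compound 4 the estimated value in this assay is 150 nM, with a range from 15 nM to 1500 nM.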

Compound 4, concentration for 50% growth inhibition: 28800 nM
For compound 4 the middle estimate is 190-fold (2.28 log units) below the measured one, and the stated range ends below it.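

On an aromatic carbon para to a large group, methoxy in place of chloro moves the series toward weaker inhibition of growth in this assay, with a 7.1-fold higher number from compound 1 to compound 4 (0.85 log units; beyond the scatter). Among these compounds, this is the first step that can be read as a size, and its direction shows that, at this place, methoxy offers no gain over chloro. A methoxy group as such is therefore not enough to bring a compound to the assay limit, which is a limit and not a number, and which compound 4 stays far from, unlike the two other methoxy-bearing compounds: the limit of < 10 nM in this assay, at which 2 of the 4 values shown sit.

Steps from compound 2 or compound 3 to the other compounds cannot be read, so the data give no size for any effect of where the methoxy sits or of the two methyl groups on the core. On these data alone, it also remains open whether a hydrogen, an amine or a carboxylic acid at this same place would give a lower number than chloro, or whether any group here would keep the number as high as it stands in compound 1 and compound 4.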